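This account rests on a few compounds, and the source may have more. Where it says the series, first, only, none or still open, it means among the compounds named here.

The series shares the core of compound 1 `O=C(NCC1(c2ccccc2)CCCCC1)Nc1ccccc1`, which carries a phenyl on the amide-type nitrogen. In an assay on microsomes from intestine for inhibition of acyl-CoA:cholesterol acyltransferase (Oryctolagus cuniculus) (a higher number here means a weaker inhibitor, a lower number a stronger inhibitor), compound 1 gives 2300 nM. Compound 2 `CC(C)c1ccc(NC(=O)NCC2(c3ccccc3)CCCCC2)cc1` gives 1500 nM in this assay, and compound 3 `CCOC(=O)c1ccc(NC(=O)NCC2(c3ccccc3)CCCCC2)cc1` gives 6100 nM. Among these three numbers compound 1 stands second highest: compound 2 is nearest, with a 1.5-fold lower number from compound 1 to compound 2 (0.19 log units; within the scatter), and compound 3 furthest, with a 2.7-fold higher number from compound 1 to compound 3 (0.42 log units; beyond the scatter). Between the two substituted analogues there is a 4.1-fold higher number from compound 2 to compound 3 (0.61 log units; beyond the scatter).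

Compound 4 `O=C(NCC1(c2ccccc2)CCCCC1)Nc1cccc(Cl)c1Cl` is not yet measured. It differs from compound 1 in one place: 2,3-dichlorophenyl in place of phenyl on an amide-type nitrogen. Both measured steps from compound 1 also alter this same ring, each by a single group on an aromatic carbon; neither involves chlorine, and neither introduces two groups at once, so they bear on the new change only loosely. They show that changes on this ring have moved the number modestly at most, the isopropyl step within the scatter and the ethoxycarbonyl step beyond it but modest. Nothing measured fixes the direction for two chlorines. The expectation for compound 4 in this assay is therefore a step of modest size, leaning toward a somewhat lower number, a 1.9-fold lower number from compound 1 to compound 4 (0.28 log units; within the scatter). Compound 4 is estimated at 1200 nM, with a range of 400 nM to 3500 nM.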

Compound 4, half-maximal inhibitory concentration: 1300 nM
Compound 4: middle estimate off by 1.1-fold (0.03 log units), on the low side; low and high end bracket the measured number.
By their numbers in this assay, from the lowest: compounds 4, 2 and 1 (each within the scatter of the next); then compound 3.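

In this assay, replacing phenyl with 2,3-dichlorophenyl on the amide-type nitrogen gives a 1.8-fold lower number from compound 1 to compound 4 (0.25 log units; within the scatter), so this step stays within the scatter even though it places chlorine on the ring and introduces two groups at once. Of the three changes to this ring from compound 1, the isopropyl and 2,3-dichlorophenyl steps lie within the scatter, while only the ethoxycarbonyl step to compound 3 lies beyond it, so carrying substituents does not by itself separate a compound from compound 1 here. No measurement shown bears on the reason for this result.

Still open, going by these compounds, is what a single chlorine would do on this ring, and whether the two chlorines of compound 4 each contribute or offset one another within a step this small. Also open is how a carboxylic acid or an amine on this ring would compare with the ethoxycarbonyl group of compound 3, the only substituent shown with a step beyond the scatter from compound 1.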